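Phenyl to 3,5-dimethylphenyl on the sulfonyl sulfur

The source may report more compounds than this note shows. Statements on the series, on what has been measured and on what is new or still open speak of the compounds shown alone.

Compound 1: `O=S(=O)(c1cccnc1)N1[C@H](CO)CC[C@@H]1c1ccc(F)cc1` — > 20000 nM
Compound 2: `O=S(=O)(c1ccccc1)N1[C@H](CO)CC[C@@H]1c1ccc(F)cc1` — > 19000 nM

Of the compounds shown here, two have been measured in an assay on isolated protein for inhibition of transient receptor potential cation channel subfamily A member 1 (Homo sapiens); a lower number here means a stronger inhibitor, a higher number a weaker inhibitor. Compound 1 is reported only as a limit of the assay, > 20000 nM. Compound 2 likewise is reported only as a limit, > 19000 nM. Among the measured compounds shown here, the one measured step, a step that the two limits leave unreadable from compound 1 to compound 2, therefore cannot be read, since both ends sit at limits: the limit of > 19000 nM in this assay, at which 1 of the 2 values shown sits, and (the limit of > 20000 nM in this assay, at which 1 of the 2 values shown sits). So compound 2 stands at a limit, with no number to anchor it.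

Compound 3, `Cc1cc(C)cc(S(=O)(=O)N2[C@H](CO)CC[C@@H]2c2ccc(F)cc2)c1`, carries 3,5-dimethylphenyl in place of phenyl on a sulfonyl sulfur. For the measured compounds named here, no measured step bears on this change; the only step known does not yield a size, and nothing in the data gives the added methyl groups a measured effect. The expectation for compound 3 therefore rests on compound 2 alone, and the step of an at least 1.2-fold lower number from compound 2 to compound 3 (0.10 log units; that floor lies within the scatter) is expected to be small or not readable beyond the scatter. Compound 3 is accordingly estimated at 15000 nM, within the range 3000 nM to 50000 nM, with a sizeable chance that only a limit is again reported.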

Compound 3, half-maximal inhibitory concentration in the transient receptor potential cation channel subfamily A member 1 assay: 290 nM
Compound 3: the middle estimate sits 52-fold (1.71 log units) above what was measured; the whole stated range lies above it.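

Among the compounds shown here, in the transient receptor potential cation channel subfamily A member 1 assay the sulfonyl sulfur position proves able to carry real inhibition, which the earlier compounds could not show: the change from phenyl gives an at least 65-fold lower number from compound 2 to compound 3 (1.81 log units; beyond the scatter), and the change from pyridin-3-yl gives an at least 68-fold lower number from compound 1 to compound 3 (1.83 log units; beyond the scatter). Both sizes are floors, since each step starts from a limit of the assay and not from a number, so how large the steps truly are cannot be read. The same change from phenyl to 3,5-dimethylphenyl also shifts a physicochemical assay for lipophilicity, at pH 7.4 (a lower number here means a more polar compound, a higher number a more lipophilic compound), where compound 2 gives 2.2 and compound 3 gives 3.2. The stronger inhibition may owe something to the higher lipophilicity of compound 3, though this single pair cannot separate that shift from any other effect of the two methyl groups: the measured distribution coefficient of compound 2, 2.2, and of compound 3, 3.2, a number 1.00 log units higher (beyond the scatter)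

The compounds shown leave open whether a single methyl group would be enough or whether both are needed for a step of this size. They also leave open whether chlorine atoms or methoxy groups in place of the two methyl groups would hold the inhibition, which would help show whether it follows lipophilicity or depends on the methyl groups themselves.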